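Carbonyl aryl exchange: working notes on one series

A few compounds are considered here, and "the series" means these few. Any claim that something is new, unique, unknown or untested is made for them only; others in the source may bear on it.

Measured compounds:
compound 1 `CC(C)(C)Cc1c(-c2ccc(F)cc2)sc(N)c1C(=O)c1ccc(Cl)cc1`: 1%
compound 2 `CC(C)(C)Cc1c(Br)sc(N)c1C(=O)c1cccc(C(F)(F)F)c1`: 1%
compound 3 `COc1ccc(-c2sc(N)c(C(=O)c3ccc(Cl)cc3)c2CC(C)(C)C)cc1`: 1%

In an assay on CHO cells for displacement of a labelled ligand from adenosine receptor A1 (Homo sapiens), read by scintillation counting, tested at 10 uM (on this read-out lower numbers stand for less inhibition and higher numbers for more inhibition at the one concentration tested (going by the name of the read-out)), compound 1 gives 1%, compound 2 gives 1% and compound 3 gives 1%. Compound 3 therefore stands level with compounds 1 and 2, none of the three parted from another beyond the scatter. Within the data shown here, the one single-point step measured, no change at the digits printed from compound 1 to compound 3 (within the scatter), shows no change. Compound 4 `COc1ccc(-c2sc(N)c(C(=O)c3cccc(C(F)(F)F)c3)c2CC(C)(C)C)cc1` differs from compound 3 by 3-(trifluoromethyl)phenyl in place of 4-chlorophenyl on a carbonyl carbon. Among the measured compounds shown here, no measured step touches the aryl on the carbonyl carbon; compound 2 carries the same 3-(trifluoromethyl)phenyl there but differs from compound 3 in a second place, so only its value can be set beside that of compound 3, and both are equally low. For the measured compounds named here, with every value so far at the same level, the expected step of a number 1 percentage points higher from compound 3 to compound 4 (within the scatter) is none beyond the scatter. Compound 4 is estimated at 2%, range 0% to 12%.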

Compound 4, a percentage reported as inhibition, at one concentration (the size of the read-out at that concentration, not a potency): 2%
For compound 4 middle estimate and measured number coincide at the digits printed; low and high end bracket the measured number.
By their numbers in this assay, from the lowest: compounds 1, 2, 3 and 4 (each within the scatter of the next).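

In this assay, the aryl on the carbonyl carbon now has a step in one place: 3-(trifluoromethyl)phenyl in place of 4-chlorophenyl gives a number 1 percentage points higher from compound 3 to compound 4 (within the scatter), so this exchange does not part the two compounds. On an aromatic carbon, 4-methoxyphenyl in place of bromo gives a number 1 percentage points higher from compound 2 to compound 4 (within the scatter), again with nothing beyond the scatter. No supporting data bear on this result.

Going by these compounds, whether an amine or a carboxylic acid in place of the aryl on the carbonyl carbon would give clear inhibition stays open. Also open, on these data alone, is whether either exchange would matter in a compound with clear inhibition.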